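The compounds below may be only part of what the source reports. "The series", "measured", "known", "first", "only" and "open" are said of these compounds alone.

Within the data shown here, compound 3, `COc1cc(-n2cnc3ccc(-c4ccccc4)cc32)cc(OC)c1OC`, stands at the upper end of the numbers so far in a functional assay on MCF7 cells (Homo sapiens) for antiproliferative activity, read by MTT assay, with a stated time of 72 h; on this read-out higher numbers stand for weaker inhibition and lower numbers for stronger inhibition: compound 3 gives 2290 nM, the highest of the two numbers, with compound 2, `COc1ccc(-c2ccc3ncn(-c4cc(OC)c(OC)c(OC)c4)c3c2)cc1F`, nearest at 520 nM. Compound 1, `COc1cc(-n2cnc3ccc(-c4ccccc4Cl)cc32)cc(OC)c1OC`, is recorded only as a limit of this assay, > 10000 nM (the limit of > 10000 nM in this assay, at which 1 of the 3 values shown sits).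

Compound 4, `COc1cccc(-c2ccc3ncn(-c4cc(OC)c(OC)c(OC)c4)c3c2)c1`, differs from compound 3 in one place: methoxy in place of hydrogen on an aromatic carbon. Among the measured compounds shown here, two measured steps bear on this. The step of a 4.4-fold higher number from compound 2 to compound 3 (0.64 log units; beyond the scatter) shows that a phenyl carrying a methoxy together with a fluoro gives a lower number than bare phenyl. The step of an at least 4.3-fold lower number from compound 1 to compound 3 (0.64 log units; beyond the scatter) shows that a chloro on the phenyl drives the number to the limit, so substitution on this ring can cut either way. For the measured compounds named here, a methoxy alone, placed meta to a large group, is a smaller change than the one seen between compound 2 and compound 3, so a lowering on the order of a 1.6-fold lower number from compound 3 to compound 4 (0.21 log units; within the scatter) is expected rather than the full step, and staying within the scatter is possible.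

Compound 4 is therefore expected to give about 1400 nM in this assay, most likely between 500 nM and 4000 nM.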

Compound 4, half-maximal inhibitory concentration: 1610 nM
For compound 4 the middle estimate is 1.2-fold (0.06 log units) below the measured one; the range from low to high includes it.
By their numbers in this assay, from the lowest: compound 2; then compounds 4 and 3 (each within the scatter of the next). At a limit, above all of these: compound 1.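

In this assay, a methoxy alone on this aromatic carbon of the phenyl does not move the number beyond the scatter: a 1.4-fold lower number from compound 3 to compound 4 (0.15 log units; within the scatter). The lower number of compound 2 therefore does not follow from a methoxy on the phenyl as such, for 3-methoxyphenyl still leaves a clear gap to 3-fluoro-4-methoxyphenyl, a 3.1-fold higher number from compound 2 to compound 4 (0.49 log units; beyond the scatter). Compound 1 stands at a limit of the assay and not at a number, so the change from its 2-chlorophenyl to 3-methoxyphenyl can be read only as a bound, an at least 6.2-fold lower number from compound 1 to compound 4 (0.79 log units; beyond the scatter), and the true size of that step stays unknown: the limit of > 10000 nM in this assay, at which 1 of the 4 values shown sits.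

The compounds shown do not separate what the fluoro and the methoxy of compound 2 each contribute, and 3-fluorophenyl and 4-methoxyphenyl would be the pieces that divide that step. Going by these compounds, how an amine, a carboxylic acid or a longer chain such as ethoxy would read on this ring also remains open.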